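A Methoxy Group Added to Compound 3

The source may report more compounds than this note shows. Statements on the series, on what has been measured and on what is new or still open speak of the compounds shown alone.

The measured compounds, with their values in an ADME assay on CHO-K1 cells (Cricetulus griseus) for cytotoxicity, read by MTT assay, with a stated time of 24 h; on this read-out lower numbers stand for stronger inhibition and higher numbers for weaker inhibition:
compound 1, `O=[N+]([O-])c1cc(Sc2nnnn2C2CCCCC2)cc([N+](=O)[O-])c1`, gives 153000 nM
compound 2, `O=[N+]([O-])c1cc(-c2nnn(Cc3cccc(F)c3)n2)cc([N+](=O)[O-])c1`, gives 315000 nM
compound 3, `O=[N+]([O-])c1cc(-c2nnnn2Cc2ccccc2)cc([N+](=O)[O-])c1`, gives 18000 nM

Compound 3 stands lowest of the three numbers in this assay. The nearest is compound 1, whose number is higher by a margin that goes beyond the scatter of repeated measurements, and compound 2 lies furthest away, also beyond the scatter. Among these three, compound 3 is therefore the strongest inhibitor of cell growth in this read-out.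

Compound 4, `COc1ccc(Cn2nnnc2-c2cc([N+](=O)[O-])cc([N+](=O)[O-])c2)cc1`, keeps the shared core and its benzyl group and differs from compound 3 in one place: methoxy in place of hydrogen on an aromatic carbon. Going by the values given here, no pair of measured compounds shows what such a single change does in this assay, so there is no measured step to lean on. A small group of this kind, without ring or charge, is expected to shift the number little, so the step from a 1.1-fold higher number from compound 3 to compound 4 (0.05 log units; within the scatter) is estimated to stay within the scatter, in no clear direction. Compound 4 is accordingly expected to give about 20000 nM in this assay, with a likely range from 7000 nM to 60000 nM.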

Compound 4, half-maximal inhibitory concentration: 21000 nM
Beside the measured number, compound 4's estimate is 1.1-fold (0.02 log units) below it, and the stated range covers the measured number.
By their numbers in this assay, from the lowest: compounds 3 and 4 (each within the scatter of the next); then compound 1; then compound 2.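

Going by these compounds alone, the first single change that can be read in this assay is phenyl to 4-methoxyphenyl, and it gives a 1.2-fold higher number from compound 3 to compound 4 (0.07 log units; within the scatter) as its whole effect on the number. Compound 3 and compound 4 therefore cannot be told apart here, which shows that this assay tolerates a methoxy group on this aromatic carbon, para to a large group, without a clear change. No other data are at hand to explain this result.

This single pair cannot show whether another group, such as an amine or a carboxylic acid, would leave the number equally unchanged at this place, or whether methoxy would do so elsewhere on the ring. Compound 1 and compound 2 differ from compound 3 in more than one place, so they cannot answer either question.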